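The source may hold more compounds than are shown below. What is called first, only, known or untested is meant among the compounds shown, and "the series" means these compounds.

Four compounds share one core, a carbonyl carried on a saturated chain that ends in an aromatic group. Compound 1 `O=C(CCCCC#Cc1ccccn1)c1ncc(-c2ccccn2)o1` carries a pyridin-2-yl group on a triple-bonded carbon and in an assay for inhibition of Fatty-acid amide hydrolase 1 (Rattus norvegicus) (on this read-out lower numbers stand for stronger inhibition and higher numbers for weaker inhibition), compound 1 gives 280 nM. Compound 2 `O=C(CCCCC#Cc1ccc([N+](=O)[O-])cc1)c1ncc(-c2ccccn2)o1` puts a 4-nitrophenyl group in its place and in this assay compound 2 gives 31 nM, a change of a 9.0-fold lower number from compound 1 to compound 2 (0.96 log units; beyond the scatter). Compound 3 `O=C(CCCCCCc1ccccc1C(=O)O)c1ncc(-c2ccccn2)o1` has a saturated chain ending in a 2-carboxyphenyl group. In this assay, within the data shown here, compound 3 reaches only a limit of > 600 nM, so no exact number is known for it; it is the one compound that sits at the limit of > 600 nM in this assay, at which 1 of the 3 values shown sits.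

Compound 4 `O=C(CCCCCCc1ccc(Cl)cc1)c1ncc(-c2ccccn2)o1` differs from compound 3 in one place: 4-chlorophenyl in place of 2-carboxyphenyl on a saturated chain carbon, six bonds along the chain from a carbonyl carbon. Among the measured compounds shown here, no measured step covers this exact change. For the measured compounds named here, the one step that has been measured, from compound 1 to compound 2, shows that swapping the terminal aromatic group on this core can shift the number by a modest amount. Since compound 3 is known only as a limit, the step to compound 4 is expected to run toward a lower number, of the size an at least 4.0-fold lower number from compound 3 to compound 4 (0.60 log units; beyond the scatter). Compound 4 is therefore estimated at 150 nM in this assay, within a range from 40 nM to 600 nM.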

Compound 4, inhibition constant: 2.7 nM
Beside the measured number, compound 4's estimate is 56-fold (1.74 log units) above it, and the stated range ends above it.
By their numbers in this assay, from the lowest: compound 4; then compound 2; then compound 1. At a limit, above all of these: compound 3.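

On this saturated chain, the group at the place six bonds along the chain from a carbonyl carbon can decide almost the whole of the inhibition seen in this assay: 4-chlorophenyl in place of 2-carboxyphenyl gives an at least 220-fold lower number from compound 3 to compound 4 (2.34 log units; beyond the scatter). Among these compounds, the one earlier step, between the two compounds with a triple bond in the chain, was modest, whereas this one is large, so swapping the aromatic group can matter far more on this core than compounds 1 and 2 alone showed. The true size of the new step remains unknown, since its starting point is a limit and not an exact number: the limit of > 600 nM in this assay, at which 1 of the 4 values shown sits.

The change removes 2-carboxyphenyl and brings in 4-chlorophenyl in one move, so the compounds shown cannot separate the loss of the carboxylic acid from the gain of the chlorine, or either of these from the shift of the substituent around the ring; a plain phenyl, a 2-chlorophenyl or a 4-carboxyphenyl in the same place would begin to do so. Also open, as far as these compounds go, is how a 4-chlorophenyl group would behave on the triple-bonded chain of compounds 1 and 2.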